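Hydroxyphenyl swap on a nitroimidazole oxadiazole thioether

This account rests on a few compounds, and the source may have more. Where it says the series, first, only, none or still open, it means among the compounds named here.

Measured so far:
compound 1 `COc1ccccc1-c1nnc(SCCn2c([N+](=O)[O-])cnc2C)o1` 30500 nM
compound 2 `Cc1ncc([N+](=O)[O-])n1CCSc1nnc(-c2ccccc2O)o1` 30500 nM
compound 3 `Cc1cccc(-c2nnc(SCCn3c([N+](=O)[O-])cnc3C)o2)c1O` 35900 nM

Three compounds share a core in which a nitroimidazole is linked through a thioethyl chain to an oxadiazole carrying an aryl group, and all three were tested in a functional assay on SGC-7901 cells (Homo sapiens) for cytotoxicity, read by MTT assay, with a stated time of 48 h; a higher number here means a weaker inhibitor, a lower number a stronger inhibitor. Compound 1 gives 30500 nM and stands level with compound 2 at the digits shown, the two together being the lowest of the three numbers; compound 3 is the furthest away, with a 1.2-fold higher number from compound 1 to compound 3 (0.07 log units; within the scatter). The step of no change at the digits printed from compound 1 to compound 2 (within the scatter) shows that removing the methyl from the oxygen leaves the number unchanged, and a 1.2-fold higher number from compound 2 to compound 3 (0.07 log units; within the scatter) shows that adding a methyl to the ring carbon changes it only within the scatter.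

Compound 4 `Cc1ccc(-c2nnc(SCCn3c([N+](=O)[O-])cnc3C)o2)c(O)c1` is not yet measured. Relative to compound 1 it carries 2-hydroxy-4-methylphenyl in place of 2-methoxyphenyl on an aromatic carbon. The relevant measured steps are those from compound 1 to compound 2 and from compound 2 to compound 3, both within the scatter, and from compound 1 to compound 3, also within the scatter. Within the data shown here, compound 4 differs from compound 3 only in where the methyl sits on the hydroxyphenyl ring, a change for which no step is available. The expectation is therefore a step of a 1.1-fold higher number from compound 1 to compound 4 (0.03 log units; within the scatter), no change beyond the scatter. Compound 4 is estimated at 33000 nM, with a range from 16000 nM to 70000 nM.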

Compound 4, half-maximal inhibitory concentration: 36700 nM
Beside the measured number, compound 4's estimate is 1.1-fold (0.05 log units) below it; the range from low to high includes it.
By their numbers in this assay, from the lowest: compounds 1, 2, 3 and 4 (each within the scatter of the next).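

In this assay, among these compounds, moving the methyl on the hydroxyphenyl group, a change the earlier compounds could not address, gives a 1.0-fold higher number from compound 3 to compound 4 (0.01 log units; within the scatter), so the 2-hydroxy-3-methylphenyl and 2-hydroxy-4-methylphenyl groups cannot be told apart at this aromatic carbon. Placing a methyl on the ring of compound 2 in this new way gives a 1.2-fold higher number from compound 2 to compound 4 (0.08 log units; within the scatter), and the full exchange of 2-methoxyphenyl for 2-hydroxy-4-methylphenyl gives a 1.2-fold higher number from compound 1 to compound 4 (0.08 log units; within the scatter), which extends to a second methyl placement the earlier finding that these small changes stay within the scatter. No evidence is available that bears on this result.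

All four compounds carry closely similar groups at this position, with only a hydroxyl, a methoxy or a methyl varying on the phenyl ring, so the compounds shown cannot tell whether this position is insensitive to change in general. On these data alone, it remains open whether an amine, a carboxylic acid, a chlorine atom or a longer alkyl chain on that ring would give a number beyond the scatter of these four.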